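The source may report more compounds than this note shows. Statements on the series, on what has been measured and on what is new or still open speak of the compounds shown alone.

Compound 2 `CC(C)(C)c1ccc(S(=O)(=O)Nc2ccc(Cl)cc2-c2ncccc2CO)cc1` gives 89 nM in a functional assay on isolated protein for antagonist activity at C-C chemokine receptor type 9 (Homo sapiens), read by calcium flux, with a stated time of 10 min (on this read-out higher numbers stand for weaker inhibition and lower numbers for stronger inhibition), the lowest of the three numbers in hand; compound 1 `CC(C)(C)c1ccc(S(=O)(=O)Nc2ccc(Cl)cc2-c2ncccc2N)cc1` gives 95 nM and compound 3 `CC(C)(C)c1ccc(S(=O)(=O)Nc2ccc(Cl)cc2-c2c(O)ccc[n+]2[O-])cc1` gives 491 nM. The step of a 1.1-fold lower number from compound 1 to compound 2 (0.03 log units; within the scatter) lies within the scatter, whereas a 5.5-fold higher number from compound 2 to compound 3 (0.74 log units; beyond the scatter) and a 5.2-fold higher number from compound 1 to compound 3 (0.71 log units; beyond the scatter) are modest losses. Compound 4 `CC(C)(C)c1ccc(S(=O)(=O)Nc2ccc(Cl)cc2-c2nccc(C(N)=O)c2O)cc1` differs from compound 2 by a group of 10 heavy atoms (6 carbon, 2 nitrogen, 2 oxygen; one six-membered aromatic ring with 1 hetero atom) in place of a group of 8 heavy atoms (6 carbon, 1 nitrogen, 1 oxygen; one six-membered aromatic ring with 1 hetero atom), on an aromatic carbon. Among the measured compounds shown here, the only measured step that likewise brings in a hydroxy is a 5.5-fold higher number from compound 2 to compound 3 (0.74 log units; beyond the scatter), a modest loss; the carboxamide has no precedent among the measured compounds. A modest weakening is therefore expected for compound 4, a 2.5-fold higher number from compound 2 to compound 4 (0.39 log units; beyond the scatter), though a step within the scatter cannot be ruled out. Compound 4 is estimated at 220 nM in this assay, with a range of 70 nM to 700 nM.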

Compound 4, half-maximal inhibitory concentration: 52 nM
For compound 4 the middle estimate is 4.2-fold (0.63 log units) above the measured one; measured number outside the range, below it.
By their numbers in this assay, from the lowest: compounds 4, 2 and 1 (each within the scatter of the next); then compound 3.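

In this assay the larger group carrying hydroxy and carboxamide is tolerated at this position, with a 1.7-fold lower number from compound 2 to compound 4 (0.23 log units; within the scatter) and a 1.8-fold lower number from compound 1 to compound 4 (0.26 log units; within the scatter). A hydroxy on this ring therefore need not cost activity, and compound 3 stands apart, with a 9.4-fold lower number from compound 3 to compound 4 (0.98 log units; beyond the scatter). No available measurement accounts for these steps.

Hydroxy and carboxamide enter together, so their separate contributions cannot be told apart from these compounds. Going by these compounds, whether a carboxylic acid or a nitrile in place of the carboxamide would hold the number remains open.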